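This account rests on a few compounds, and the source may have more. Where it says the series, first, only, none or still open, it means among the compounds named here.

Measured in a functional assay on MCF7 cells (Homo sapiens) for cytotoxicity, read by MTT assay, with a stated time of 24 h; a lower number here means a stronger inhibitor, a higher number a weaker inhibitor:
compound 1 `O=C(NC(=S)Nc1nc2ccccc2s1)c1ccc([N+](=O)[O-])cc1`: 33800 nM
compound 2 `O=C(NC(=S)Nc1nc2cc([N+](=O)[O-])ccc2s1)c1ccccc1`: 41600 nM
compound 3 `CCCCC(=O)NC(=S)Nc1nc2cc([N+](=O)[O-])ccc2s1`: > 100000 nM, a limit of the assay and not a number

Compound 2 and compound 1 lie within the scatter of each other in this assay. The value of compound 3 is a limit only. Among the measured compounds shown here, the single one-site step known, an at least 2.4-fold higher number from compound 2 to compound 3 (0.38 log units; beyond the scatter), concerns the substituent on the carbonyl carbon, not the fused ring, and is bounded by the limit of > 100000 nM in this assay, at which 1 of the 3 values shown sits. Compound 4 `O=C(NC(=S)Nc1nc2ccccc2s1)c1ccccc1` differs from compound 2 as follows: hydrogen in place of nitro on an aromatic carbon. For the measured compounds named here, no measured step removes a nitro from the fused ring, so no step beyond the scatter is expected here. Compound 4 is expected to give about 35000 nM, within 15000 nM to 90000 nM. The step expected is a 1.2-fold lower number from compound 2 to compound 4 (0.08 log units; within the scatter).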

Compound 4, half-maximal inhibitory concentration: 37300 nM
For compound 4 the middle estimate is 1.1-fold (0.03 log units) below the measured one, within the range that was stated.
By their numbers in this assay, from the lowest: compounds 1, 4 and 2 (each within the scatter of the next). At a limit, above all of these: compound 3.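

In this assay the nitro on the fused ring proves dispensable at this level of activity, with a 1.1-fold lower number from compound 2 to compound 4 (0.05 log units; within the scatter) as the step for hydrogen in its place. Removing the nitro from the aromatic ring on the carbonyl carbon gives a 1.1-fold higher number from compound 1 to compound 4 (0.04 log units; within the scatter) and so is equally silent, which means neither nitro position separates these compounds. Nothing shown gives a reason for this lack of response.

As far as these compounds go, whether an amine or a carboxylic acid at either aromatic position would shift the number stays open. So does the effect of a methoxy group at those same places.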